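The source may hold more compounds than are shown below. What is called first, only, known or untested is meant among the compounds shown, and "the series" means these compounds.

Working notes on the chalcone series in an ADME assay on Vero cells (Chlorocebus sabaeus) for cytotoxicity, read by MTT assay; a lower number here means a stronger inhibitor, a higher number a weaker inhibitor. Compound 1, `C=CCOc1cc(OC)c(C(=O)/C=C/c2ccccc2Br)c(OCC=C)c1`, gives 13900 nM, the lowest of the two numbers in hand. Compound 3, `C=CCOc1cc(OC)c(C(=O)/C=C/c2cc(OCC=C)c(Br)c(OCC=C)c2)c(OCC=C)c1`, gives 96300 nM, a higher number, beyond the usual scatter. Compound 2, `COc1ccc(/C=C/C(=O)c2c(O)cc(O)cc2OC)cc1`, has "not determined" (no result reported) in this assay, so it adds nothing to the comparison. Compound 4, `C=CCOc1cc(OC)c(C(=O)/C=C/c2ccc([N+](=O)[O-])cc2)c(OCC=C)c1`, has not yet been measured. Relative to compound 1 the change is 4-nitrophenyl in place of 2-bromophenyl on a double-bonded chain carbon bound to a double-bonded chain carbon. Within the data shown here, no step between measured compounds isolates this exchange, so the direction cannot be read from the series. The step from compound 1 to compound 4 is expected to be small, a 1.4-fold higher number from compound 1 to compound 4 (0.16 log units; within the scatter), within or near the scatter. Compound 4 is therefore estimated at 20000 nM, with a range from 6000 nM to 65000 nM.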

Compound 4, half-maximal inhibitory concentration: 12600 nM
The estimate for compound 4 lay 1.6-fold (0.20 log units) above the measured number, and the stated range covers the measured number.
By their numbers in this assay, from the lowest: compounds 4 and 1 (each within the scatter of the next); then compound 3.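

In this assay, among these compounds, the exchange of 2-bromophenyl for 4-nitrophenyl on a double-bonded chain carbon bound to a double-bonded chain carbon gives a 1.1-fold lower number from compound 1 to compound 4 (0.04 log units; within the scatter) and is the first step that changes one place alone. These two groups are therefore not separated at this place by this read-out. No measured evidence bears on this result. As far as these compounds go, whether 4-aminophenyl or 4-carboxyphenyl at the same place would separate from compound 1 stays open. With a single step at this place, no trend across groups can be drawn.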